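Extending the Propyl Chain from Compound 3 to Compound 4

A few compounds are considered here, and "the series" means these few. Any claim that something is new, unique, unknown or untested is made for them only; others in the source may bear on it.

Compound 1 `CCc1ccccc1NC(=O)N[C@H](C)c1ccccc1` gives 92% in an ADME assay on the whole organism with Oryza sativa as the target, tested at 10 uM; on this read-out lower numbers stand for a stronger effect and higher numbers for a weaker effect at the one concentration tested.
Compound 2 `CCCc1ccc(NC(=O)N[C@H](C)c2ccccc2)cc1` gives 35% in this assay.
Compound 3 `CCCc1ccc(NC(=O)N[C@@H](C)c2ccccc2)cc1` gives 73% in this assay.

Among the three numbers measured, compound 3 holds the second highest value. Its nearest neighbour is compound 1, which lies above it beyond the scatter; the furthest is compound 2, which lies below it beyond the scatter. For the measured compounds named here, the one single-point step measured so far is a number 38 percentage points higher from compound 2 to compound 3 (beyond the scatter), a large step that rests on the fact that compounds 2 and 3 differ only in the configuration as drawn alone, since the two compounds carry the same atoms and bonds.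

Compound 4 `CCCCc1ccc(NC(=O)N[C@@H](C)c2ccccc2)cc1` differs from compound 3 by methyl in place of hydrogen on a saturated chain carbon, three bonds along the chain from an aromatic carbon, so the propyl becomes a butyl. Going by the values given here, no measured step touches the length of this chain: the step from compound 2 to compound 3 changes configuration, not the chain, and the difference between compound 1 and compound 2 involves more than one change. The read-out is therefore expected to stay close to that of compound 3, with a step of a number 3 percentage points lower from compound 3 to compound 4 (within the scatter) that is not expected to exceed the scatter. For compound 4 the estimated value in this assay is 70%, with a range from 50% to 90%.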

Compound 4, a percentage reported as activity, at one concentration (the size of the read-out at that concentration, not a potency): 60%
Estimate against measurement, compound 4: 10 percentage points above; low and high end bracket the measured number.
By their numbers in this assay, from the lowest: compound 2; then compound 4; then compound 3; then compound 1.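

In this assay, going from propyl to butyl gives a number 13 percentage points lower from compound 3 to compound 4 (beyond the scatter), the first measured sign that the length of this chain affects the read-out. The change is only methyl in place of hydrogen on a saturated chain carbon, three bonds along the chain from an aromatic carbon, yet it moves the number in the direction of a stronger effect while the configuration stays as drawn in compound 3. Nothing measured here gives a reason for this step.

On these data alone, what a pentyl or a longer chain would do at this place remains open, as does a chain ending in an amine or a carboxylic acid. Also open, as far as these compounds go, is whether butyl would give a like step in the configuration drawn in compound 2.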